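Thiophene substituent changes on the aminothiophene core

The source may report more compounds than this note shows. Statements on the series, on what has been measured and on what is new or still open speak of the compounds shown alone.

Measured compounds:
compound 1 `CC(C)Nc1sc(C(=O)c2ccc(Br)s2)c(N)c1C#N` — 122 nM
compound 2 `CC(C)Nc1sc(C(=O)c2cc(Cl)cs2)c(N)c1C#N` — 575 nM
compound 3 `CC(C)Nc1sc(C(=O)c2cc(Br)cs2)c(N)c1C#N` — 599 nM

In an assay for inhibition of Maternal embryonic leucine zipper kinase (Homo sapiens), read by ADP-Glo, with a stated time of 0.5 h (on this read-out higher numbers stand for weaker inhibition and lower numbers for stronger inhibition), compound 1 gives the lowest number of the three; its steps to the other two, a 4.7-fold higher number from compound 1 to compound 2 (0.67 log units; beyond the scatter) and a 4.9-fold higher number from compound 1 to compound 3 (0.69 log units; beyond the scatter), both lie beyond the scatter, so it is the strongest inhibitor shown. Compound 2 and compound 3 give numbers within the scatter of each other, a 1.0-fold higher number from compound 2 to compound 3 (0.02 log units; within the scatter).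

The next compound, compound 4 `CC(C)Nc1sc(C(=O)c2ccc(-c3cccc(O)c3)s2)c(N)c1C#N`, differs from compound 1 by 3-hydroxyphenyl in place of bromo on an aromatic carbon. Within the data shown here, none of the measured steps bears directly on this change: the two steps from compound 1 move the halogen to another ring carbon, and the step from compound 2 to compound 3 swaps one halogen for another without effect. What is shown is only that the substituent at the carbon next to the ring sulfur matters for this assay. The size and direction of the step for compound 4 therefore cannot be anchored; a step of a 1.4-fold lower number from compound 1 to compound 4 (0.13 log units; within the scatter) is expected, with a wide range. For compound 4 the estimate in this assay is 90 nM, ranging from 15 nM to 500 nM.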

Compound 4, half-maximal inhibitory concentration: 350 nM
Beside the measured number, compound 4's estimate is 3.9-fold (0.59 log units) below it, within the range that was stated.
By their numbers in this assay, from the lowest: compound 1; then compounds 4, 2 and 3 (each within the scatter of the next).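

In this assay the change to 3-hydroxyphenyl gives a 2.9-fold higher number from compound 1 to compound 4 (0.46 log units; beyond the scatter) and so is a modest loss, beyond the scatter, for a six-membered aromatic ring in place of bromo on the carbon next to the ring sulfur. This carbon is therefore not restricted to a halogen: inhibition persists with a much larger group there, although bromo remains the better of the two substituents at this carbon. Nothing available here accounts for the size of this step.

On these data alone, it remains open whether the step belongs to the phenyl ring itself or to its hydroxyl, which a plain phenyl or a 3-aminophenyl at this carbon would separate. Also open, as far as these compounds go, is how a group without an aromatic ring, such as a morpholine or a short alkyl chain, would read here.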